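This account rests on a few compounds, and the source may have more. Where it says the series, first, only, none or still open, it means among the compounds named here.

Measured so far:
- compound 1, `Cc1cc(C(=O)O)ccc1CN1CC[C@H](OC(CO)c2cc(Cl)cc(Cl)c2)[C@@H]1c1ccccc1` — 133000 nM
- compound 2, `COc1cccc([C@@H](CO)O[C@H]2CCCN(Cc3ccc(C(=O)O)cc3C)[C@H]2c2ccccc2)c1` — 81000 nM

Both compounds were tested in an assay on isolated protein for activation of cGMP-dependent protein kinase 1 (Homo sapiens), read by ADP-Glo, with stated times of 30 min and 2 h, in the presence of a further agent that is not named here; on this read-out higher numbers stand for an effect only at larger amounts of compound and lower numbers for an effect already at smaller amounts. Compound 2 has the lower of the two numbers, but its nearest neighbour, compound 1, lies within the scatter of repeated measurements, so the two results cannot be told apart with confidence; they simply show that both compounds act only at large amounts.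

Compound 3, `Cc1cc(C(=O)O)ccc1CN1CCC[C@H](O[C@H](CO)c2ccccc2)[C@@H]1c1ccccc1`, has not yet been measured. It differs from compound 2 in one place: hydrogen in place of methoxy on an aromatic carbon. Put another way, the 3-methoxyphenyl group of compound 2 becomes a plain phenyl group in compound 3.

Among the compounds with values here, with no pair of measured compounds differing in one place, there is no step to lean on. The two values at hand, both weak and close together, suggest the shared core tolerates changes on that ring without a large shift. The expected step from compound 2 to compound 3 in this assay is therefore small, a 1.2-fold higher number from compound 2 to compound 3 (0.09 log units; within the scatter), likely no more than the scatter.

For compound 3 the estimated value in this assay is 100000 nM, within a range of 40000 nM to 250000 nM.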

Compound 3, half-maximal effective concentration: 25000 nM
For compound 3 the middle estimate is 4.0-fold (0.60 log units) above the measured one, and the stated range ends above it.
By their numbers in this assay, from the lowest: compound 3; then compounds 2 and 1 (each within the scatter of the next).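

Within the data shown here, removing the methoxy group gives the first comparison of two compounds that differ in one place, and in this assay this change produces a 3.2-fold lower number from compound 2 to compound 3 (0.51 log units; beyond the scatter) and so shows that the group on this aromatic carbon does affect the result. Here the plain phenyl group does better than the 3-methoxyphenyl group, although the step is modest and compound 3, at 25000 nM, still needs a large amount of compound to show an effect. Nothing measured here explains why the number falls when the methoxy group leaves, so the step stands as an observation only.

Going by these compounds, with a single step at this position, it remains open whether the methoxy group is a poor fit in particular or whether any group on this carbon would raise the number compared with hydrogen. A fluorine, a hydroxyl or the longer ethoxy group on the same aromatic carbon would help to separate these two readings, and would show whether any group there can bring the number below that of the plain phenyl compound.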